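The source may report more compounds than this note shows. Statements on the series, on what has been measured and on what is new or still open speak of the compounds shown alone.

Measured compounds:

Compound 1, `CCc1ccccc1OS(=O)(=O)c1cccc(NC(=O)NCCCCl)c1`: 25000 nM
Compound 2, `O=C(NCCCCl)Nc1cccc(S(=O)(=O)Oc2ccc(O)cc2)c1`: 51000 nM
Compound 3, `CCNC(=O)Nc1cccc(S(=O)(=O)Oc2ccccc2CC)c1`: 31000 nM

The three measured compounds were examined in a functional assay on MCF7 cells (Homo sapiens) for cytotoxicity, read by sulforhodamine B assay, with a stated time of 48 h; on this read-out higher numbers stand for weaker inhibition and lower numbers for stronger inhibition. Compound 1 gives 25000 nM in this assay. Compound 2 differs from compound 1 by 4-hydroxyphenyl in place of 2-ethylphenyl on an oxygen, and this brought a 2.0-fold higher number from compound 1 to compound 2 (0.31 log units; beyond the scatter). Compound 3 differs from compound 1 by hydrogen in place of chloromethyl on a saturated chain carbon, two bonds along the chain from an amide-type nitrogen, with a 1.2-fold higher number from compound 1 to compound 3 (0.09 log units; within the scatter), so compound 1 and compound 3 cannot be told apart on this read-out.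

Compound 4, `CCNC(=O)Nc1cccc(S(=O)(=O)Oc2ccc(O)cc2)c1`, has not yet been measured in this assay. It differs from compound 3 by 4-hydroxyphenyl in place of 2-ethylphenyl on an oxygen. This is the same change that turned compound 1 into compound 2, where it produced a 2.0-fold higher number from compound 1 to compound 2 (0.31 log units; beyond the scatter). The two cores on which the change is made differ by hydrogen in place of chloromethyl on a saturated chain carbon, two bonds along the chain from an amide-type nitrogen, a difference that left the number unchanged within the scatter. On that basis a step of about the same size is expected here, namely a 1.9-fold higher number from compound 3 to compound 4 (0.29 log units; within the scatter). Compound 4 is therefore estimated to give 60000 nM in this assay, with a plausible range from 35000 nM to 110000 nM.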

Compound 4, half-maximal inhibitory concentration: 64000 nM
The estimate for compound 4 lay 1.1-fold (0.03 log units) below the measured number, within the range that was stated.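

In this assay, 4-hydroxyphenyl in place of 2-ethylphenyl on the oxygen brought a 2.1-fold higher number from compound 3 to compound 4 (0.31 log units; beyond the scatter), and this step matched the one seen on the core of compound 1: the same change on two cores in this assay, a 2.0-fold higher number (0.31 log units; beyond the scatter) from compound 1 to compound 2 and a 2.1-fold higher number (0.31 log units; beyond the scatter) from compound 3 to compound 4, 1.0-fold (0.01 log units) apart, within the scatter of two such steps The other change, hydrogen in place of chloromethyl on the saturated chain carbon, gave a 1.3-fold higher number from compound 2 to compound 4 (0.10 log units; within the scatter), so it stayed within the scatter with either group on the oxygen: the same change on two cores in this assay, a 1.2-fold higher number (0.09 log units; within the scatter) from compound 1 to compound 3 and a 1.3-fold higher number (0.10 log units; within the scatter) from compound 2 to compound 4, 1.0-fold (0.01 log units) apart, within the scatter of two such steps Together these steps show that, across these four compounds, the two changes behaved independently and the effect of the first carried from one core to the other, but they show this only for one pair of cores in this one assay, and they do not show why the number rises or whether the same step would appear on any other core.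

The exchange also alters two things at once, removing the ethyl group and adding the hydroxyl group, so the compounds shown leave open how much of the step belongs to each. As far as these compounds go, it also remains open whether the step would persist with a plain phenyl group, with an amine or a carboxylic acid on that ring, or with a longer chain on the amide-type nitrogen.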